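This account rests on a few compounds, and the source may have more. Where it says the series, first, only, none or still open, it means among the compounds named here.

Measured so far in an assay on isolated protein for inhibition of Rho-associated protein kinase 2 (Homo sapiens); a higher number here means a weaker inhibitor, a lower number a stronger inhibitor:
compound 1, `Nc1nccc(-c2ccc3nc(C4COc5ccc(F)cc5C4)oc3c2)n1`, gives 15 nM.
compound 2, `Nc1nccc(-c2ccc3nc(C4COc5ccc(C(=O)NCc6ccccc6)cc5C4)[nH]c3c2)n1`, gives only a limit of the assay, < 1 nM.

Compound 1 thus carries the only number shown; the other entry is a limit, (the limit of < 1 nM in this assay, at which 1 of the 2 values shown sits). Going by the values given here, no step between measured compounds is available to calibrate the change. Compound 3, `Nc1nccc(-c2ccc3nc(C4COc5ccccc5C4)oc3c2)n1`, differs from compound 1 by hydrogen in place of fluoro on an aromatic carbon. Without a measured step to lean on, the step from compound 1 to compound 3 is expected to be a 1.5-fold higher number from compound 1 to compound 3 (0.17 log units; within the scatter), close to the scatter and, if anything, slightly weaker. Compound 3 is therefore estimated at 22 nM, with a range from 7 nM to 65 nM.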

Compound 3, half-maximal inhibitory concentration: 27 nM
For compound 3 the middle estimate is 1.2-fold (0.09 log units) below the measured one, within the range that was stated.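

In this assay, going by these compounds alone, hydrogen in place of fluoro on an aromatic carbon gives a 1.8-fold higher number from compound 1 to compound 3 (0.26 log units; within the scatter), the first measured step. At this position, then, the fluoro and the hydrogen cannot be told apart in this assay, since compound 1 and compound 3 lie within the scatter of each other. Nothing shown bears on why this step has the size it has. From the compounds shown here alone, it remains open whether a methoxy, an amine or a carboxylic acid on the same aromatic carbon would give a step beyond the scatter.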